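Methyl on the N-phenyl ring of compound 3

This account rests on a few compounds, and the source may have more. Where it says the series, first, only, none or still open, it means among the compounds named here.

Measured compounds: compound 1 `Cc1cccc(C(=O)N(C(=S)OCCN2C(=O)c3ccccc3C2=O)c2ccc(Cl)cc2)c1`, 58000 nM; compound 2 `O=C1c2ccccc2C(=O)N1CCOC(=S)N(C(=O)c1ccc(Cl)c(Cl)c1)c1ccccc1`, 52000 nM; compound 3 `O=C1c2ccccc2C(=O)N1CCOC(=S)N(C(=O)c1ccc(Cl)c([N+](=O)[O-])c1)c1ccccc1`, 51000 nM.

In an ADME assay on MT4 cells (Homo sapiens) for cytotoxicity, read by MTT assay (a lower number here means that less compound is tolerated, a higher number that more compound is tolerated), compound 3 sits together with compound 2 and compound 1; all three numbers lie within the scatter of one another, and the step of a 1.0-fold lower number from compound 2 to compound 3 (0.01 log units; within the scatter) confirms this. Compound 4 `Cc1ccc(N(C(=O)c2ccc(Cl)c([N+](=O)[O-])c2)C(=S)OCCN2C(=O)c3ccccc3C2=O)cc1` differs from compound 3 by methyl in place of hydrogen on an aromatic carbon. Among the compounds with values here, none of the measured steps touches this ring: the one step available concerns the other aromatic ring, and compound 1 differs from compound 2 in two places. The three numbers show that changes on the other ring left this assay flat. For compound 4 a step of a 1.0-fold lower number from compound 3 to compound 4 (0.01 log units; within the scatter) is expected, that is, none beyond the scatter. Compound 4 is therefore estimated at 50000 nM, in the range 25000 nM to 100000 nM.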

Compound 4, half-maximal cytotoxic concentration: 47000 nM
For compound 4 the middle estimate is 1.1-fold (0.03 log units) above the measured one; low and high end bracket the measured number.
By their numbers in this assay, from the lowest: compounds 4, 3, 2 and 1 (each within the scatter of the next).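

This is the only step shown on the ring that carries the para methyl: in this assay, the change from phenyl to 4-methylphenyl gives a 1.1-fold lower number from compound 3 to compound 4 (0.04 log units; within the scatter). The flat picture seen so far with changes on the other aromatic ring therefore also holds for this single methyl on this ring, with compound 4 lying within the scatter of compound 3. The data offer no explanation for this result. The compounds shown leave open whether an amine, a carboxylic acid or a longer chain in this place would stay equally flat.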